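Swapping Fluoro for Nitro on the Terminal Phenyl Ring

The source may hold more compounds than are shown below. What is called first, only, known or untested is meant among the compounds shown, and "the series" means these compounds.

Going by the values given here, compound 1 `Fc1ccc(NC(=S)N/N=C/c2ccc(Oc3ccc(F)cc3)cc2)cc1` is one of three compounds measured in a physicochemical assay for lipophilicity, in phosphate buffer, measured as octanol-water partition, with a stated time of 24 h (a lower number here means a more polar compound, a higher number a more lipophilic compound), where compound 1 gives 5.19. That is the second highest of the three numbers, though the gap to compound 2 lies within the scatter. Compound 2 `Fc1ccc(Oc2ccc(/C=N/NC(=S)Nc3ccccc3)cc2)cc1` gives 5.09, and the step of a number 0.10 log units lower from compound 1 to compound 2 (within the scatter) is within the scatter. Compound 3 `Fc1ccc(Oc2ccc(/C=N/NC(=S)Nc3ccc(Cl)cc3)cc2)cc1` gives 5.84; the step of a number 0.65 log units higher from compound 1 to compound 3 (beyond the scatter) is modest, as is the step of a number 0.75 log units higher from compound 2 to compound 3 (beyond the scatter).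

Compound 4 `O=[N+]([O-])c1ccc(Oc2ccc(/C=N/NC(=S)Nc3ccc(F)cc3)cc2)cc1` has not yet been measured. It differs from compound 1 in one place: nitro in place of fluoro on an aromatic carbon. Among the compounds with values here, none of the measured steps introduces a nitro group, so none bears directly on this change; they only show that exchanging hydrogen, fluoro and chloro at this position moves the number by no more than a modest amount. Because compound 1 gives 5.19 and the counted difference adds hydrogen-bond acceptors, a somewhat lower number is expected, and the step is estimated as a number 0.39 log units lower from compound 1 to compound 4 (beyond the scatter). Compound 4 is therefore expected to give 4.8, with a range from 4.3 to 5.3.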

Compound 4, partition coefficient: 4.89
Estimate against measurement, compound 4: 0.09 log units below, within the range that was stated.
By their numbers in this assay, from the lowest: compounds 4, 2 and 1 (each within the scatter of the next); then compound 3.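

In this assay the exchange of fluoro for nitro gives a number 0.30 log units lower from compound 1 to compound 4 (within the scatter), so on the core of compound 1 this swap, which brings in hydrogen-bond acceptors, leaves the number within the scatter. It is also the first step shown at this aromatic carbon, since the earlier steps all changed the other fluoro of compound 1. Nothing measured here gives a reason for this result.

As far as these compounds go, it remains open whether other groups at this carbon, such as an amine, a carboxylic acid or a methoxy group, would also stay this close to compound 1. Also open, from the compounds shown here alone, is whether nitro would give a similarly small step on the cores of compound 2 and compound 3, which carry hydrogen and chloro at the other site.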